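The source may report more compounds than this note shows. Statements on the series, on what has been measured and on what is new or still open speak of the compounds shown alone.

Measured compounds:
compound 1 `COc1ccc(C(=O)c2cc(OC)c(OC)c(OC)c2)cc1NC(=O)/C=C/c1cc(OC)c(OC)c(OC)c1`, in a functional assay on B16 cells (Mus musculus) for cytotoxicity, read by MTT assay, with a stated time of 72 h (on this read-out higher numbers stand for weaker inhibition and lower numbers for stronger inhibition), compound 1 gives 1200 nM
compound 2 `COc1ccc(C(=O)c2cc(OC)c(OC)c(OC)c2)cc1NC(=O)/C=C/c1ccc(F)c(F)c1`, compound 2 gives 6500 nM
compound 3 `COc1cc(C(=O)c2cc(OC)c(OC)c(OC)c2)cc(NC(=O)/C=C/c2cc(OC)c(OC)c(OC)c2)c1OC`, compound 3 gives 2500 nM

Among the compounds with values here, compound 3 stands second highest of the three numbers in this assay: compound 1 sits at a lower number, the step being a 2.1-fold higher number from compound 1 to compound 3 (0.32 log units; beyond the scatter), while compound 2 sits at a higher number; no single-point step joins compound 3 and compound 2, so only their two values are set side by side. Compound 4 `COc1ccc(/C=C/C(=O)Nc2cc(C(=O)c3cc(OC)c(OC)c(OC)c3)cc(OC)c2OC)cc1N` is not yet measured. It differs from compound 3 in one place: 3-amino-4-methoxyphenyl in place of 3,4,5-trimethoxyphenyl on a double-bonded chain carbon bound to a double-bonded chain carbon.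

Within the data shown here, one measured step bears on this change, the replacement of the same 3,4,5-trimethoxyphenyl at the same place in compound 1: a 5.4-fold higher number from compound 1 to compound 2 (0.73 log units; beyond the scatter). That replacement brought in 3,4-difluorophenyl; the present one brings in 3-amino-4-methoxyphenyl, a different group, so the earlier step is a guide only to direction, not to size. Taking that precedent, a modest rise in the number is expected for compound 4, a 1.6-fold higher number from compound 3 to compound 4 (0.20 log units; within the scatter), with a fair chance of no change beyond the scatter. Compound 4 is expected to give 4000 nM in this assay, within a range of 1200 nM to 13000 nM.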

Compound 4, half-maximal inhibitory concentration: 12700 nM
For compound 4 the middle estimate is 3.2-fold (0.50 log units) below the measured one, and the stated range covers the measured number.
By their numbers in this assay, from the lowest: compound 1; then compound 3; then compounds 2 and 4 (each within the scatter of the next).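

On the core of compound 3, as on the core of compound 1, moving away from 3,4,5-trimethoxyphenyl on a double-bonded chain carbon bound to a double-bonded chain carbon weakens inhibition in this assay, with a 5.1-fold higher number from compound 3 to compound 4 (0.71 log units; beyond the scatter) standing beside the earlier 5.4-fold higher number from compound 1 to compound 2 (0.73 log units; beyond the scatter). Across these two pairs the direction therefore holds on both cores and for two different entering groups, 3,4-difluorophenyl and 3-amino-4-methoxyphenyl, and neither pair goes against it, although each core carries only one replacement. The entering group in compound 4 has fewer heavy atoms than the group it replaces and brings a hydrogen-bond donor, but no measurement in hand ties the rise to either difference.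

The compounds shown leave open whether the amino group, the loss of methoxy groups or both account for the step, which a hydroxy group in place of the amino group or a plain 4-methoxyphenyl at this place could help to separate. They also leave open how 3,4-difluorophenyl and 3-amino-4-methoxyphenyl would rank on one shared core.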